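The compounds below may be only part of what the source reports. "The series", "measured", "known", "first", "only" and "open" are said of these compounds alone.

Compound 1, `Nc1ccccc1NC(=O)c1ccc(CSC(=S)N2CCN(c3ccncc3)CC2)cc1`: 90.7%
Compound 2, `CN(C(=S)SCc1ccc(C(=O)Nc2ccccc2N)cc1)c1cccnc1`: 87.7%

In a functional assay on A-375 cells (Homo sapiens) for antiproliferative activity, read by CCK-8 assay, with a stated time of 72 h, tested at 8 uM (on this read-out lower numbers stand for a weaker effect and higher numbers for a stronger effect at the one concentration tested), compound 1 gives 90.7% of the two numbers shown, and compound 2 gives 87.7%, which lies within the usual scatter of that result. Compound 3, `Cc1ccc(N2CCN(C(=S)SCc3ccc(C(=O)Nc4ccccc4N)cc3)CC2)cc1`, has not been measured yet. It differs from compound 1 in one place: 4-methylphenyl in place of pyridin-4-yl on an amine nitrogen in a ring. Among the compounds with values here, no pair of measured compounds shows the effect of this change, so nothing more than the two results above can guide the expectation. The expected change, a number 5.7 percentage points lower from compound 1 to compound 3 (within the scatter), is small and, if anything, downward. Compound 3 is estimated to give 85%, within a range from 65% to 95%.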

Compound 3, a percentage reported as inhibition, at one concentration (the size of the read-out at that concentration, not a potency): 26.4%
For compound 3 the middle estimate is 58.6 percentage points above the measured one; measured number outside the range, below it.
By their numbers in this assay, from the lowest: compound 3; then compounds 2 and 1 (each within the scatter of the next).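

In this assay, 4-methylphenyl in place of pyridin-4-yl on the ring amine nitrogen gives a number 64.3 percentage points lower from compound 1 to compound 3 (beyond the scatter), so the group at this position strongly affects the result. The group that leaves has a ring nitrogen and a hydrogen-bond acceptor, and the group that enters has neither, but this is only a count and does not show that either feature matters. Nothing measured here explains the step.

The compounds shown leave open whether losing the ring nitrogen or adding the methyl accounts for the step. Plain phenyl on the same nitrogen would separate the two.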